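The compounds below may be only part of what the source reports. "The series", "measured", "known", "first", "only" and "open" are said of these compounds alone.

Measured so far:
Compound 1 `CCCCn1cc(C(=O)Nc2ccc(C)c(S(=O)(=O)N3CCOCC3)c2)c(-c2ccc(C)cc2)n1`: 52.5 nM
Compound 2 `Cc1ccc(-c2nn(CCCCO)cc2C(=O)Nc2ccc(C)c(S(=O)(=O)N3CCOCC3)c2)cc1`: 130 nM

In an assay on isolated protein for antagonist activity at Bile acid receptor (Homo sapiens), read by TR-FRET, with a stated time of 20 min (on this read-out lower numbers stand for stronger inhibition and higher numbers for weaker inhibition), compound 1 gives 52.5 nM and compound 2 gives 130 nM. Among the measured compounds shown here, of these two numbers compound 2 has the higher one, and the single recorded step between them, a 2.5-fold higher number from compound 1 to compound 2 (0.39 log units; beyond the scatter), is the hydroxy group entering on the saturated chain. Compound 3 `Cc1ccc(-c2nn(-c3ccccc3)cc2C(=O)Nc2ccc(C)c(S(=O)(=O)N3CCOCC3)c2)cc1` carries a different group on that same aromatic nitrogen: phenyl in place of 4-hydroxybutyl on an aromatic nitrogen. For the measured compounds named here, this change takes away the hydroxy group that went with the higher number of compound 2, but it also exchanges the chain for an aromatic ring, and no measured step covers such an exchange. Going by the values given here, the one relevant step points toward a lower number for compound 3, with an uncertain size, so the expected step is a 1.9-fold lower number from compound 2 to compound 3 (0.27 log units; within the scatter). Compound 3 is therefore estimated in this assay at 70 nM, with a range from 25 nM to 250 nM.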

Compound 3, half-maximal inhibitory concentration: 47 nM
Compound 3: the middle estimate sits 1.5-fold (0.17 log units) above what was measured; the range from low to high includes it.
By their numbers in this assay, from the lowest: compounds 3 and 1 (each within the scatter of the next); then compound 2.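

Until now this aromatic nitrogen had carried only saturated chains; compound 3 shows that, in this assay it can also bear a six-membered aromatic ring of carbon only and keep a number in the range of compound 1. Measured against the hydroxy-bearing chain, phenyl gives a 2.8-fold lower number from compound 2 to compound 3 (0.44 log units; beyond the scatter) and measured against the plain butyl chain, it gives a 1.1-fold lower number from compound 1 to compound 3 (0.05 log units; within the scatter) so phenyl and butyl cannot be told apart here. Among these three compounds, compound 2 alone stands apart from the other two, and it is also the only one with a hydroxy group.

Still open, from the compounds shown here alone, is how a benzyl group, a methyl group, or a phenyl ring carrying a chlorine or a methoxy group would read at this nitrogen, and whether an amine at the end of the butyl chain would match the hydroxy group. No supporting data are available to explain any of these differences.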